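Phenyl for Methyl on the Saturated Ring, Seen Twice

The compounds below may be only part of what the source reports. "The series", "measured", "known", "first", "only" and "open" are said of these compounds alone.

Measured so far in a physicochemical assay for lipophilicity; on this read-out higher numbers stand for higher lipophilicity and lower numbers for lower lipophilicity:
compound 1 `CCOC(=O)C1C(=O)C=C(Nc2ccccc2N2CCN(C)CC2)CC1c1ccccc1`: 4.35
compound 2 `CCOC(=O)C1C(=O)C=C(Nc2ccccc2N2CCN(C)CC2)CC1C`: 3.02
compound 3 `CCOC(=O)C1C(=O)C=C(Nc2cccc(N3CCN(C)CC3)c2)CC1C`: 3.05

Compounds 2 and 3 are built from the same atoms joined differently; the difference between the two cores is not broken down here. In this assay compound 2 gives 3.02 and compound 3 gives 3.05, two numbers within the usual scatter of each other, so no order between them can be claimed.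

Compound 1 arises from compound 2 by one change, (phenyl in place of methyl on a saturated ring carbon). The step of a number 1.33 log units higher from compound 2 to compound 1 (beyond the scatter) is large and beyond the scatter.

Compound 4 `CCOC(=O)C1C(=O)C=C(Nc2cccc(N3CCN(C)CC3)c2)CC1c1ccccc1` is not yet measured. It arises from compound 3 by phenyl in place of methyl on a saturated ring carbon, the same change at the same place. Within the data shown here, with only one earlier example, the expectation rests on that single step: compound 4 is expected to lie higher than compound 3 by about a number 1.33 log units higher from compound 3 to compound 4 (beyond the scatter), because the same change gave a number 1.33 log units higher from compound 2 to compound 1 (beyond the scatter). The estimate for compound 4 in this assay is therefore 4.38, expected between 4 and 4.8.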

Compound 4, partition coefficient: 4.37
Compound 4: middle estimate off by 0.01 log units, on the high side; measured number inside the range.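

In this assay, phenyl in place of methyl on a saturated ring carbon gives a number 1.32 log units higher from compound 3 to compound 4 (beyond the scatter), a large step of much the same size as the earlier one, a number 1.33 log units higher from compound 2 to compound 1 (beyond the scatter). The two cores are built from the same atoms joined differently, and in this pair of cases the change carried from one core to the other with its size intact, so a step read on one core served well as a guide on the other. Still, two pairs make no rule for cores beyond these, and no measurement shown here explains why the step has this size.

The compounds shown carry only methyl and phenyl at this saturated ring carbon, so what a longer chain, an amine or a carboxylic acid would give there remains open. Also open, from the compounds shown here alone, is whether phenyl in place of methyl would give a step of this size on any other core.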